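Two stereocentres changed from compound 2 to compound 3

The compounds below may be only part of what the source reports. "The series", "measured", "known", "first", "only" and "open" are said of these compounds alone.

Within the data shown here, in a functional assay on HL-60 cells (Homo sapiens) for antiproliferative activity, read by MTT assay (a lower number here means a stronger inhibitor, a higher number a weaker inhibitor), compound 2 (`CCC[C@H]1O[C@H](COCc2ccccc2)[C@@H](OCc2ccccc2)[C@H](OCc2ccccc2)[C@H]1O`) gives 28200 nM, the only number so far. Compound 3 (`CCC[C@@H]1O[C@H](COCc2ccccc2)[C@H](OCc2ccccc2)[C@H](OCc2ccccc2)[C@H]1O`) has the same atoms and bonds and differs only in configuration as drawn: the two compounds have the same atoms and bonds and differ only in configuration as drawn: 2 of 5 stereo elements differ; a stereocentre at a saturated ring carbon is drawn R in compound 2 and S in compound 3; a stereocentre at a saturated ring carbon is drawn R in compound 2 and S in compound 3. Both changed stereocentres sit at saturated ring carbons, drawn R in compound 2 and S in compound 3. No measured step sizes this change. Among the measured compounds shown here, the only guide is compound 1 (`CC(C)C[C@@H]1O[C@H](COCc2ccccc2)[C@H](OCc2ccccc2)[C@H](OCc2ccccc2)[C@H]1O`), which shares the configuration drawn for compound 3 but carries a different chain. In this assay, compound 1 gives "not active" (no number reported), with no number reported. A modest move towards weaker inhibition is therefore expected, an estimated 1.3-fold higher number from compound 2 to compound 3 (0.13 log units; within the scatter). Compound 3 is estimated at 38000 nM, with an expected range of 13000 nM to 100000 nM.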

Compound 3, half-maximal inhibitory concentration: "not active" (no number reported)
Nothing numeric was reported for compound 3, so the estimate cannot be set against anything.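

No step can be read from compound 2 to compound 3: in this assay compound 3 gives "not active" (no number reported), without a number. The compounds shown leave open what either changed stereocentre does alone in this assay.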